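This account rests on a few compounds, and the source may have more. Where it says the series, first, only, none or still open, it means among the compounds named here.

Measured so far:
compound 1 `CCOC(=O)N1N=C(c2ccc(OC)cc2)CC1c1cc(OC)c(OC)c(OC)c1`: 9400 nM
compound 2 `COC(=O)N1N=C(c2cccc(O)c2)CC1c1cc(OC)c(OC)c(OC)c1`: 650 nM

In a functional assay on HepG2 cells (Homo sapiens) for antiproliferative activity, read by MTT assay, with a stated time of 48 h (a higher number here means a weaker inhibitor of growth, a lower number a stronger inhibitor of growth), compound 2 has the lower of the two numbers, 650 nM, and its gap to compound 1 lies beyond the scatter. Compound 3 `CCOC(=O)N1N=C(c2cccc(O)c2)CC1c1cc(OC)c(OC)c(OC)c1` changes compound 2 in one place: methyl in place of hydrogen on a saturated chain carbon bound to an oxygen next to a carbonyl group, so methoxycarbonyl becomes ethoxycarbonyl. Going by the values given here, no measured pair shows this change alone, since compound 1 and compound 2 differ in more than one place. The expectation is therefore a small shift toward a higher number, probably none beyond the scatter, with an estimated 1.2-fold higher number from compound 2 to compound 3 (0.09 log units; within the scatter). The estimate for compound 3 is 800 nM, with an expected range from 300 nM to 2500 nM.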

Compound 3, concentration for 50% growth inhibition: 1790 nM
Estimate against measurement, compound 3: 2.2-fold (0.35 log units) below; the range from low to high includes it.
By their numbers in this assay, from the lowest: compound 2; then compound 3; then compound 1.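

Going from methoxycarbonyl to ethoxycarbonyl in this assay gives a 2.8-fold higher number from compound 2 to compound 3 (0.44 log units; beyond the scatter) and so this single added methyl on the saturated chain carbon counts for more than the scatter. Going by these compounds alone, with ethoxycarbonyl held fixed, 3-hydroxyphenyl in place of 4-methoxyphenyl gives a 5.3-fold lower number from compound 1 to compound 3 (0.72 log units; beyond the scatter) as the first reading of that swap on its own. No measurement at hand explains either step.

Going by these compounds, whether a longer chain such as propoxycarbonyl would raise the number further stays open. So does how much of the aryl swap belongs to the hydroxyl itself, which 3-methoxyphenyl or 4-hydroxyphenyl could help separate.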